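The compounds below may be only part of what the source reports. "The series", "measured", "known", "first", "only" and "open" are said of these compounds alone.

Measured in a functional assay on HL-60 cells (Homo sapiens) for antiproliferative activity, read by MTT assay, with a stated time of 72 h; on this read-out higher numbers stand for weaker inhibition and lower numbers for stronger inhibition:
Compound 1 `COc1ccc(OCCCON2C(N)=NC(N)=NC23CCOCC3)cc1`: 1670 nM
Compound 2 `NC1=NC2(CCOCC2)N(OCCCOc2ccc(Cl)cc2)C(N)=N1`: 330 nM

Compound 2 holds the lower of the two numbers, at 330 nM. Compound 3 `NC1=NC2(CCOCC2)N(OCCCOc2cccc(Cl)c2Cl)C(N)=N1` has 2,3-dichlorophenyl in place of 4-chlorophenyl on an oxygen on a saturated carbon. Among the measured compounds shown here, only one measured step bears on this change, a 5.1-fold lower number from compound 1 to compound 2 (0.70 log units; beyond the scatter), where chloro replaced methoxy on an aromatic carbon. For the measured compounds named here, that step was modest, and no measured compound carries a second chlorine, so only a small shift towards a lower number in this assay is expected. The expected change is a 1.5-fold lower number from compound 2 to compound 3 (0.18 log units; within the scatter). For compound 3 the estimated value is 220 nM, with an expected range from 70 nM to 700 nM.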

Compound 3, half-maximal inhibitory concentration: 440 nM
Compound 3: middle estimate off by 2.0-fold (0.30 log units), on the low side; the measured number falls inside the stated range.
By their numbers in this assay, from the lowest: compounds 2 and 3 (each within the scatter of the next); then compound 1.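

In this assay the change to 2,3-dichlorophenyl gives a 1.3-fold higher number from compound 2 to compound 3 (0.12 log units; within the scatter), so the second chlorine and the altered pattern bring no shift that can be told from the scatter. Against 4-methoxyphenyl, the same group gives a 3.8-fold lower number from compound 1 to compound 3 (0.58 log units; beyond the scatter), so the advantage over the methoxy compound holds with either chlorinated ring. No evidence is at hand to explain this result. The compounds shown leave open whether a bromo or trifluoromethyl group on the aromatic ring, or a longer chain to the oxygen, would move the number further.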